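Nitro placement on the benzamide aryl: compound 1 to compound 4

The compounds below may be only part of what the source reports. "The series", "measured", "known", "first", "only" and "open" are said of these compounds alone.

Notes on the trimethoxyphenyl amide series. Compound 1 `COc1cc(N(C)C(=O)c2ccccc2)cc(OC)c1OC` is measured in a functional assay on ONS-76 cells (Homo sapiens) for cytotoxicity, read by MTT assay, with a stated time of 72 h; on this read-out higher numbers stand for weaker inhibition and lower numbers for stronger inhibition. Compound 1 gives only a limit, >= 125000 nM, not a number. Compound 2 `COc1cc(N(C)C(=O)c2ccc([N+](=O)[O-])cc2)cc(OC)c1OC` likewise reaches only a limit, >= 125000 nM. The step that the two limits leave unreadable from compound 1 to compound 2 is therefore unreadable from these two limits. Compound 3 `COc1cc(N(C)C(=O)N(C)c2ccccc2)cc(OC)c1OC` has "not determined" (no result reported) in this assay. Compound 4 `COc1cc(N(C)C(=O)c2cccc([N+](=O)[O-])c2)cc(OC)c1OC` differs from compound 1 as nitro in place of hydrogen on an aromatic carbon. Among the measured compounds shown here, the single measured step bearing on it is the nitro step from compound 1 to compound 2, which sits at the limit where both values lie (the limit of >= 125000 nM in this assay, at which 2 of the 3 values shown sit). No readable step exists, so compound 4 is expected to remain at the limit, estimated at 125000 nM within 80000 nM to 300000 nM, meaning a step of a number no higher from compound 1 to compound 4 (the limit leaves the size open) that is expected to be none beyond the scatter.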

Compound 4, half-maximal inhibitory concentration: >= 125000 nM
Compound 4: no number, only a limit; the forecaster's own chance of this, stated with the estimate: 85%; the middle value sits exactly at the limit.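

No step can be read between compound 1 and compound 4, as both stay at a limit: the limit of >= 125000 nM in this assay, at which 3 of the 4 values shown sit.

The compounds shown leave open whether nitro on the aromatic ring changes the cytotoxicity of the shared core at all.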